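From chloro to bromo: what to expect for compound 4

The compounds below may be only part of what the source reports. "The series", "measured", "known", "first", "only" and "open" are said of these compounds alone.

Measured so far in a functional assay on SMMC-7721 cells (Homo sapiens) for cytotoxicity, read by MTT assay, with a stated time of 24 h (on this read-out higher numbers stand for weaker inhibition and lower numbers for stronger inhibition), as follows
- compound 1 `CN1C/C(=C\c2cccnc2)C(=O)/C(=C/c2ccccc2C(F)(F)F)C1` gives 3900 nM 
- compound 2 `O=C1/C(=C/c2cccnc2)CN(S(=O)(=O)c2ccc([N+](=O)[O-])cc2)C/C1=C\c1ccccc1C(F)(F)F` gives 15900 nM 
- compound 3 `O=C1/C(=C/c2cccnc2)CN(S(=O)(=O)c2ccc(Cl)cc2)C/C1=C\c1ccccc1C(F)(F)F` gives 4880 nM 

Two steps show where compound 3 stands: a 1.3-fold higher number from compound 1 to compound 3 (0.10 log units; within the scatter) on one side and a 3.3-fold lower number from compound 2 to compound 3 (0.51 log units; beyond the scatter) on the other. Compound 4 `O=C1/C(=C/c2cccnc2)CN(S(=O)(=O)c2ccc(Br)cc2)C/C1=C\c1ccccc1C(F)(F)F` differs in one place, bromo in place of chloro on an aromatic carbon that is, bromo in place of chloro on an aromatic carbon, para to a large group. Among the compounds with values here, no measured step makes this swap. The nearest evidence is chloro in place of nitro at that place, with a 3.3-fold lower number from compound 2 to compound 3 (0.51 log units; beyond the scatter) as its size, a change of a different kind. A step beyond the scatter is therefore not expected, and no direction is favoured. The expected change is a 1.0-fold higher number from compound 3 to compound 4 (0.01 log units; within the scatter) as a small one. Compound 4 is estimated at 5000 nM with an expected range of 2500 nM to 10000 nM in this estimate.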

Compound 4, half-maximal inhibitory concentration: 5760 nM
Beside the measured number, compound 4's estimate is 1.2-fold (0.06 log units) below it; the range from low to high includes it.
By their numbers in this assay, from the lowest: compounds 1, 3 and 4 (each within the scatter of the next); then compound 2.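

In this assay, within the data shown here, this is the first direct comparison of the two halogens at this position, and they cannot be told apart (a 1.2-fold higher number from compound 3 to compound 4 (0.07 log units; within the scatter)). Bromo, like chloro, gives a lower number than nitro (a 2.8-fold lower number from compound 2 to compound 4 (0.44 log units; beyond the scatter)), while the (4-bromophenyl)sulfonyl group cannot be separated from the methyl on the ring nitrogen (a 1.5-fold higher number from compound 1 to compound 4 (0.17 log units; within the scatter)). No measurement offered here explains these results. From the compounds shown here alone, whether an amine or a methoxy group at this place would behave like the halogens or like nitro remains open.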